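The source may hold more compounds than are shown below. What is called first, only, known or untested is meant among the compounds shown, and "the series" means these compounds.

Compound 1 `COc1cc(/C=C/C2=CC(=O)CC(c3ccc(O)c(OC)c3)N2CCCO)ccc1O`: 91%
Compound 2 `COc1cc(/C=C/C(=O)/C=C(/C=C/c2ccc(O)c(OC)c2)NCCO)ccc1O`: 96.6%

Both compounds were tested in a functional assay on Caco-2 cells (Homo sapiens) for activation, read by fluorescence, tested at 10 uM; on this read-out lower numbers stand for a stronger effect and higher numbers for a weaker effect at the one concentration tested. In this assay compound 1 gives 91% and compound 2 gives 96.6%. The two numbers lie within the usual scatter of each other, so nothing separates compound 2 from compound 1 on this read-out; both stand where the effect is weak at the concentration tested, and no ranking between them can be drawn.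

Compound 3 `COCCCNC(=C\C(=O)/C=C/c1ccc(O)c(OC)c1)/C=C/c1ccc(O)c(OC)c1` has not yet been measured. It differs from compound 2 in one place: methoxymethyl in place of hydroxy on a saturated chain carbon, two bonds along the chain from an amine nitrogen. For the measured compounds named here, no measured pair in the set shows the effect of this kind of change, so the expectation rests only on the two numbers above. Since both measured compounds sit close together at the weak end of the read-out, compound 3 is expected to stay near that level, with a step of a number 1.6 percentage points lower from compound 2 to compound 3 (within the scatter) that is expected to fall within the scatter. The estimated value for compound 3 is 95%, with a range from 84% to 104%.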

Compound 3, a percentage reported as activity, at one concentration (the size of the read-out at that concentration, not a potency): 84.8%
Beside the measured number, compound 3's estimate is 10.2 percentage points above it; the measured number falls inside the stated range.
By their numbers in this assay, from the lowest: compounds 3, 1 and 2 (each within the scatter of the next, the first and the last beyond it).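

In this assay, changing (2-hydroxyethyl)amino to (3-methoxypropyl)amino gives a number 11.8 percentage points lower from compound 2 to compound 3 (beyond the scatter). This is a modest step toward a stronger effect, and it shows that the chain on this nitrogen is not a silent spot: a change here can move the read-out beyond ordinary scatter, although the figure for compound 3 of 84.8% is still the size of a read-out at one concentration, not a potency. The change bundles two differences, since the hydroxy group with its hydrogen-bond donor leaves and a methoxymethyl group with no donor enters, while the chain also grows, and no supporting data explain the shift.

The compounds shown leave open whether the step follows the loss of the hydroxy hydrogen or the added chain length, and a 2-methoxyethyl group on the same nitrogen would help pull those two apart. Also open, on these data alone, is how the read-out would respond to an amine or a carboxylic acid at the end of this chain, or to a longer chain such as 4-methoxybutyl.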